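The source may report more compounds than this note shows. Statements on the series, on what has been measured and on what is new or still open speak of the compounds shown alone.

Of the compounds shown here, three of a shared core have been measured in a functional assay on Malme-3M cells (Homo sapiens) for inhibition, read by sulforhodamine B assay, with a stated time of 48 h; a higher number here means a weaker inhibitor of growth, a lower number a stronger inhibitor of growth. Compound 1 `COc1ccc(-c2cc(/C=C/C(=O)c3cc(OC)c(OC)c(OC)c3)[nH]n2)cc1OC` gives 2320 nM, compound 2 `COc1ccc(C(=O)/C=C/c2cc(-c3cc(OC)c(OC)c(OC)c3)n[nH]2)cc1` gives 1860 nM, and compound 3 `COc1cc(C(=O)/C=C/c2cc(-c3cc(OC)c(OC)c(OC)c3)n[nH]2)cc(OC)c1OC` gives 1860 nM. Compound 2 stands level with compound 3 at the digits printed, the two together the lowest of the three numbers, and its gap to compound 1 stays within the scatter. Going by the values given here, the only single-point step measured so far is a 1.2-fold lower number from compound 1 to compound 3 (0.10 log units; within the scatter), a methoxy in place of hydrogen on an aromatic carbon, which changes nothing beyond the scatter.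

Compound 4 `COc1cc(-c2cc(/C=C/C(=O)c3ccc(F)c(F)c3)[nH]n2)cc(OC)c1OC` differs from compound 2 by 3,4-difluorophenyl in place of 4-methoxyphenyl on a carbonyl carbon. Among the compounds with values here, no measured step concerns the aromatic ring attached to the carbonyl carbon, so the only guidance is that the one change made so far on an aromatic ring left this assay essentially unmoved. Compound 4 is therefore expected to stay close to compound 2, with a step of a 1.3-fold higher number from compound 2 to compound 4 (0.13 log units; within the scatter) that may well lie within the scatter. Compound 4 is estimated at 2500 nM, in the range 900 nM to 7000 nM.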

Compound 4, concentration for 50% growth inhibition: 2960 nM
Beside the measured number, compound 4's estimate is 1.2-fold (0.07 log units) below it, and the stated range covers the measured number.
By their numbers in this assay, from the lowest: compounds 2, 3, 1 and 4 (each within the scatter of the next).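

Going by these compounds alone, the step of a 1.6-fold higher number from compound 2 to compound 4 (0.20 log units; within the scatter) is the first to concern the aromatic ring on the carbonyl carbon, and in this assay it stays within the scatter. Here 3,4-difluorophenyl, with no hydrogen-bond acceptor, takes the place of 4-methoxyphenyl, with one, at the same count of heavy atoms, so the loss of that oxygen and the entry of two fluorines do not move the number beyond the scatter. Nothing shown gives a reason for this outcome.

Every step shown so far lies within the scatter, so it stays open whether any change at this position can move the number further. An amine or a carboxylic acid on this ring, or a longer chain in place of the ring, might show whether the position responds at all.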